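The compounds below may be only part of what the source reports. "The series", "measured", "known", "first", "only" and "open" are said of these compounds alone.

Compound 2 `COc1nc(-c2ccncc2)ccc1[C@@H](c1ccccc1)[C@@](O)(CCN(C)C)c1cccc2ccccc12` is the starting point here, and the question is how harmful it is to cells in a toxicity assay on Vero cells (Chlorocebus sabaeus) for cytotoxicity; on this read-out lower numbers stand for higher toxicity in this test and higher numbers for lower toxicity in this test. In this assay compound 2 gives no number but only a limit, > 50 ug/mL. For the measured compounds named here, the single measured neighbour, compound 1 `COc1nc(-c2cccc(Cl)c2)ccc1[C@@H](c1ccccc1)[C@@](O)(CCN(C)C)c1cccc2ccccc12`, carries a 3-chlorophenyl group where compound 2 carries pyridin-4-yl. In this assay compound 1 also gives only a limit, > 50 ug/mL. Going by the values given here, the one measured step, a step that the two limits leave unreadable from compound 1 to compound 2, thus has no readable size; all that the two values show is captured by the limit of > 50 ug/mL in this assay, at which 2 of the 2 values shown sit.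

Compound 3 `COc1nc(-c2ccc(F)cc2)ccc1[C@@H](c1ccccc1)[C@@](O)(CCN(C)C)c1cccc2ccccc12` has not yet been measured in this assay. It differs from compound 2 by 4-fluorophenyl in place of pyridin-4-yl on an aromatic carbon. Among the compounds with values here, the only measured step that bears on this kind of exchange at the same position, from compound 1 to compound 2, lies between two limits and offers no size to build on. The step from compound 2 to compound 3 is therefore expected to be a step that the limit leaves unreadable from compound 2 to compound 3, nothing beyond the usual scatter. For compound 3 the estimated result in this assay is 65 ug/mL, with a range from 30 ug/mL to 120 ug/mL, and most probably it will again be reported only as a limit.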

Compound 3, half-maximal cytotoxic concentration: > 50 ug/mL
Compound 3: only a limit was reported; the forecaster's own chance of this, stated with the estimate: 80%; the middle value does not contradict the limit.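

Compound 3 gives only a limit in this assay, > 50 ug/mL. The steps among compound 1, compound 2 and compound 3 therefore cannot be read: the limit of > 50 ug/mL in this assay, at which 3 of the 3 values shown sit.

The compounds shown leave open how far past this limit each one lies, and whether any group at this position would give a measurable number in this assay.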